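The source may report more compounds than this note shows. Statements on the series, on what has been measured and on what is new or still open speak of the compounds shown alone.

Three compounds share one core and differ in the sulfonyl-bearing group attached to it. Compound 1 `CCCS(=O)(=O)c1cccc(C#Cc2cc(Cl)ccc2OCC(=O)O)c1` gives 9 nM in an assay on CHO cells for displacement of a labelled ligand from prostaglandin D2 receptor 2 (Homo sapiens), read by scintillation counting; a higher number here means a weaker inhibitor, a lower number a stronger inhibitor. Compound 2 `CS(=O)(=O)c1ccc(C#Cc2cc(Cl)ccc2OCC(=O)O)cc1` gives 86 nM in this assay. Compound 3 `Cc1ccc(S(=O)(=O)N(C)C(C)C)cc1C#Cc1cc(Cl)ccc1OCC(=O)O` gives 3.8 nM in this assay. Compound 3 therefore holds the lowest number of the three; compound 1 sits nearest and compound 2 furthest, and both gaps lie beyond the usual scatter, so compound 3 counts as the strongest inhibitor among the measured set.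

Compound 4 `Cc1ccc(S(=O)(=O)N(C)CCCN(C)C)cc1C#Cc1cc(Cl)ccc1OCC(=O)O` has not yet been measured. It differs from compound 3 in a single place: 3-(dimethylamino)propyl in place of isopropyl on a sulfonamide nitrogen. Among the measured compounds shown here, no pair of measured compounds differs by such a change alone, so the numbers in hand give no direct guide to how this assay will answer it. What can be said is that the sulfonyl group and the remainder of the molecule stay untouched, and that the measured compounds already show several different groups on that sulfonyl being accepted. The change is expected to be small, a 2.1-fold higher number from compound 3 to compound 4 (0.32 log units; beyond the scatter), and likely to stay within the usual scatter. Compound 4 is estimated at 8 nM, with a range from 2 nM to 30 nM.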

Compound 4, inhibition constant: 287 nM
The estimate for compound 4 lay 36-fold (1.55 log units) below the measured number, and the stated range ends below it.
By their numbers in this assay, from the lowest: compound 3; then compound 1; then compound 2; then compound 4.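

Among the compounds shown here, the sulfonamide nitrogen proves far less tolerant than the earlier compounds could suggest. They differ in the whole sulfonyl-bearing group and so cannot isolate this position, whereas placing 3-(dimethylamino)propyl there instead of isopropyl gives a 76-fold higher number from compound 3 to compound 4 (1.88 log units; beyond the scatter) in this assay on its own. The entering group has 6 heavy atoms, one of them nitrogen, against 3 carbons in the leaving group, so size and the added nitrogen change together in this one step, and nothing available here explains the loss of strength.

A plain propyl or butyl chain on the same nitrogen would help separate the effect of chain length from that of the dimethylamino group, and a 3-methoxypropyl chain or a chain ending in a carboxylic acid would test what replacing that group does. Also open, from the compounds shown here alone, is how a shorter 2-(dimethylamino)ethyl chain or a piperidine ring would compare with 3-(dimethylamino)propyl, and whether the methyl group on the same sulfonamide nitrogen matters to the outcome.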